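Methoxyphenyl replacing dichlorophenyl on a benzylamine arm

A few compounds are considered here, and "the series" means these few. Any claim that something is new, unique, unknown or untested is made for them only; others in the source may bear on it.

In a functional assay on NCI-H226 cells (Homo sapiens) for inhibition, read by sulforhodamine B assay, with a stated time of 48 h (on this read-out higher numbers stand for weaker inhibition of growth and lower numbers for stronger inhibition of growth), compound 3 `Nc1cc(N)c2nc(-c3ccccc3)c(NCc3ccc(Cl)c(Cl)c3)nc2c1` gives 22400 nM, the higher of the two numbers recorded, though compound 1 `Nc1cc(N)c2nc(-c3ccccc3)c(Oc3ccc(Cl)c(Cl)c3)nc2c1` at 15100 nM sits within the usual scatter of it. Compound 2 `CCOC(=O)[C@H](CCC(=O)O)NC(=O)c1ccc(CNc2nc3cc(N)cc(N)c3nc2-c2ccccc2)cc1` is recorded only as a limit of the assay, < 100000 nM, and not as a number. Compound 4 `COc1ccc(CNc2nc3cc(N)cc(N)c3nc2-c2ccccc2)cc1` differs from compound 3 in one place: 4-methoxyphenyl in place of 3,4-dichlorophenyl on a saturated chain carbon bound to a nitrogen on an aromatic ring. For the measured compounds named here, no step between two measured compounds in this set shows the effect of such a change, so no direction beyond the scatter can be foreseen from the data. Compound 4 is therefore expected at 25000 nM, with a range from 10000 nM to 70000 nM. The expected step of a 1.1-fold higher number from compound 3 to compound 4 (0.05 log units; within the scatter) is thus modest.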

Compound 4, concentration for 50% growth inhibition: 20400 nM
For compound 4 the middle estimate is 1.2-fold (0.09 log units) above the measured one; the range from low to high includes it.
By their numbers in this assay, from the lowest: compounds 1, 4 and 3 (each within the scatter of the next).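

In this assay, for the compounds shown here, replacing 3,4-dichlorobenzyl with 4-methoxybenzyl gives a 1.1-fold lower number from compound 3 to compound 4 (0.04 log units; within the scatter), the first step that can be read at this place. Both chlorine atoms can thus leave and an oxygen-bearing methoxy group can enter without a change beyond the scatter in this read-out. Nothing measured in the data accounts for this result.

On these data alone, it remains open whether a pyridine or a morpholine in place of the 4-methoxyphenyl would shift the number beyond the scatter. The same is true of a longer chain carrying the aromatic ring.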